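One carbon fewer in a chain: a cytotoxicity comparison

The source may report more compounds than this note shows. Statements on the series, on what has been measured and on what is new or still open speak of the compounds shown alone.

Four compounds share a chain that ends in the same group and carries a sulfur bearing an oxygen; they differ in what sits on that sulfur and in how long the chain is. Compound 1 `CC(C)[S+]([O-])CCCCN=C=S` carries a branched three-carbon group on the sulfur. Compound 2 `[O-][S+](CCCCN=C=S)Cc1ccccc1` and compound 3 `[O-][S+](CCCN=C=S)Cc1ccccc1` carry a benzyl group there instead; how the core of compound 1 differs from the core of compound 2 is not broken down here. Compound 4 `CC(C)[S+]([O-])CCCN=C=S` is the shorter-chain partner of compound 1.

In an ADME assay on Vero cells (Chlorocebus sabaeus) for cytotoxicity, read by MTT assay, with a stated time of 72 h (a lower number here means a stronger inhibitor, a higher number a weaker inhibitor), compound 1 gives 10400 nM. In this assay compound 2 gives 4850 nM and compound 3 gives 10100 nM. From compound 2 to compound 3 the change is a group of 3 heavy atoms (1 carbon, 1 nitrogen, 1 sulfur; no ring) in place of a group of 4 heavy atoms (2 carbon, 1 nitrogen, 1 sulfur; no ring), on a saturated chain carbon, three bonds along the chain from a sulfur, and it made a step of a 2.1-fold higher number from compound 2 to compound 3 (0.32 log units; beyond the scatter).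

The change from compound 1 to compound 4 is a group of 3 heavy atoms (1 carbon, 1 nitrogen, 1 sulfur; no ring) in place of a group of 4 heavy atoms (2 carbon, 1 nitrogen, 1 sulfur; no ring), on a saturated chain carbon, three bonds along the chain from a sulfur, the same change at the same place. Among the compounds with values here, only one pair shows this change with measurements, so the expectation for compound 4 rests on that single pair. Because of a 2.1-fold higher number from compound 2 to compound 3 (0.32 log units; beyond the scatter) the number for compound 4 is expected to be higher than that of compound 1, by an estimated step of a 1.9-fold higher number from compound 1 to compound 4 (0.28 log units; within the scatter). The estimate for compound 4 in this assay is 20000 nM, with a likely range from 9000 nM to 45000 nM.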

Compound 4, half-maximal inhibitory concentration: 8250 nM
Beside the measured number, compound 4's estimate is 2.4-fold (0.38 log units) above it; measured number outside the range, below it.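

In this assay, removing one carbon from the chain of compound 1 gives a step of a 1.3-fold lower number from compound 1 to compound 4 (0.10 log units; within the scatter), so on this core the change cannot be told apart from the ordinary variation between repeated measurements. The steps on the two cores point in opposite directions on paper, yet the gap between them is no larger than two such steps can show by scatter alone: the same change on two cores in this assay, a 2.1-fold higher number (0.32 log units; beyond the scatter) from compound 2 to compound 3 and a 1.3-fold lower number (0.10 log units; within the scatter) from compound 1 to compound 4, 2.6-fold (0.42 log units) apart, within the scatter of two such steps. Within the data shown here, this means the series gives no firm sign that the core alters the result of shortening the chain, but it does not prove that the change carries over unchanged either, since there are only two pairs and only the step on the benzyl-bearing core lies beyond the scatter.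

The compounds shown leave open how a longer chain would read in this assay on either core, and whether more pairs of the same kind would settle if the chain length matters at all when the sulfur bears the branched three-carbon group. They also leave open what would happen with a different group on the sulfur, such as a cyclohexyl group, or with an amine in place of the group that ends the chain.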